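The source may report more compounds than this note shows. Statements on the series, on what has been measured and on what is new or still open speak of the compounds shown alone.

In an ADME assay on Huh-7 cells (Homo sapiens) for cytotoxicity, read by XTT assay, with a stated time of 2 days (on this read-out lower numbers stand for higher toxicity in this test and higher numbers for lower toxicity in this test), compound 1 `Cc1cn([C@H]2C[C@H](Br)[C@@H](CO)O2)c(=O)[nH]c1=O` gives > 100 ug/mL, which is a limit and not a number. Compound 2 `Cc1cn([C@H]2C[C@H](Cl)[C@@H](CO)O2)c(=O)[nH]c1=O` gives > 100 ug/mL, which is likewise only a limit. Compound 2 thus has no exact position on this scale, and it shares the limit of > 100 ug/mL in this assay, at which 2 of the 2 values shown sit, with compound 1. Compound 3 `Cc1cn([C@H]2C[C@H](I)[C@@H](CO)O2)c(=O)[nH]c1=O` has not yet been measured in this assay. It differs from compound 2 in a single exchange, iodo in place of chloro on a saturated ring carbon. Among the measured compounds shown here, the one measured step that bears on this change is a step that the two limits leave unreadable from compound 1 to compound 2, which involves the same ring carbon but has no readable size. It therefore gives no size or direction to carry over, and no step beyond the scatter is expected in this assay. The expected change is a step that the limit leaves unreadable from compound 2 to compound 3. For compound 3 the estimated value is 120 ug/mL, with an expected range from 50 ug/mL to 300 ug/mL.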

Compound 3, half-maximal cytotoxic concentration: > 100 ug/mL
Compound 3: only a limit was reported; the forecaster's own chance of this, stated with the estimate: 75%; the middle value does not contradict the limit.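

In this assay compound 3 gives > 100 ug/mL, which is a limit, so no step linking compound 3 with compound 1 or compound 2 can be read: the limit of > 100 ug/mL in this assay, at which 3 of the 3 values shown sit.

The compounds shown leave open whether bromo, chloro and iodo on this saturated ring carbon differ at all in this assay.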